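This account rests on a few compounds, and the source may have more. Where it says the series, first, only, none or still open, it means among the compounds named here.

In a functional assay on NCI-H460 cells (Homo sapiens) for inhibition, read by MTT assay, with a stated time of 48 h (on this read-out higher numbers stand for weaker inhibition and lower numbers for stronger inhibition), three compounds sharing one core have been tested. Compound 1 `O=C(CC(c1cccs1)C(C(=O)Nc1ccccn1)C(=O)Nc1ccccn1)c1ccccc1` gave "not active" (no number reported). Compound 2 `O=C(CC(c1ccc(Cl)cc1Cl)C(C(=O)Nc1ccccn1)C(=O)Nc1ccccn1)c1ccccc1` gave 13100 nM. Compound 3 `O=C(CC(c1c(Cl)cccc1Cl)C(C(=O)Nc1ccccn1)C(=O)Nc1ccccn1)c1ccccc1` gave 27400 nM, the higher of the two numbers available. Compound 4 `Cc1cc(C)c(C(CC(=O)c2ccccc2)C(C(=O)Nc2ccccn2)C(=O)Nc2ccccn2)c(C)c1` carries 2,4,6-trimethylphenyl in place of 2,6-dichlorophenyl, on a saturated chain carbon bound to two saturated chain carbons: 2,4,6-trimethylphenyl in place of 2,6-dichlorophenyl on a saturated chain carbon bound to two saturated chain carbons. Among the measured compounds shown here, only one measured step bears on this change, a 2.1-fold higher number from compound 2 to compound 3 (0.32 log units; beyond the scatter), and it is modest. For the measured compounds named here, it involved a change at the same place, but no measured step yet starts from a trimethylphenyl compound. In this assay, no step beyond the scatter is therefore expected, and a slightly higher number is the likelier direction. The expected step is a 1.1-fold higher number from compound 3 to compound 4 (0.04 log units; within the scatter). For compound 4 the estimate is 30000 nM, with an expected range of 13000 nM to 70000 nM.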

Compound 4, half-maximal inhibitory concentration: 23200 nM
Compound 4: the middle estimate sits 1.3-fold (0.11 log units) above what was measured; low and high end bracket the measured number.
By their numbers in this assay, from the lowest: compounds 2, 4 and 3 (each within the scatter of the next, the first and the last beyond it).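

Swapping 2,6-dichlorophenyl for 2,4,6-trimethylphenyl on a saturated chain carbon bound to two saturated chain carbons gives a 1.2-fold lower number from compound 3 to compound 4 (0.07 log units; within the scatter), and the comparison with the other dichlorophenyl compound gives a 1.8-fold higher number from compound 2 to compound 4 (0.25 log units; within the scatter). In this assay, chlorine is therefore not needed at this place for a measurable number, and the trimethylphenyl compound cannot be told apart from either dichlorophenyl compound. Nothing available explains this result. Going by these compounds, whether a plain phenyl, or a phenyl carrying a methoxy group or an amine, would also give a number at this place remains open.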